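One Methyl Group on Compound 1

The source may hold more compounds than are shown below. What is called first, only, known or untested is meant among the compounds shown, and "the series" means these compounds.

For the measured compounds named here, in a functional assay on the whole organism for inhibition, with Rattus norvegicus as the target (a higher number here means that more compound is needed for the effect, a lower number that less compound is needed), compound 1 `Oc1nnc(-c2nc3ccccc3o2)o1` gives 3 mg/kg, the lower of the two numbers so far. Compound 2 `Oc1nnc(-c2nc3cc(Cl)ccc3o2)o1` gives 16 mg/kg. Compound 3 `Cc1ccc2nc(-c3nnc(O)o3)oc2c1` changes compound 1 by methyl in place of hydrogen on an aromatic carbon. Going by the values given here, the only measured step that bears on this is chloro in place of hydrogen on an aromatic carbon, a 5.3-fold higher number from compound 1 to compound 2 (0.73 log units; beyond the scatter). That single step involves a different group, so it is a weak guide. A smaller rise is therefore expected, a 2.3-fold higher number from compound 1 to compound 3 (0.37 log units; beyond the scatter). For compound 3 the estimated value is 7 mg/kg, with an expected range of 2.5 mg/kg to 20 mg/kg.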

Compound 3, dose for half-maximal effect: 2 mg/kg
The estimate for compound 3 lay 3.5-fold (0.54 log units) above the measured number; the measured number lies below the stated range.
By their numbers in this assay, from the lowest: compounds 3 and 1 (each within the scatter of the next); then compound 2.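

In this assay, methyl in place of hydrogen on this aromatic carbon gives a 1.5-fold lower number from compound 1 to compound 3 (0.18 log units; within the scatter), so the added group leaves the number effectively unchanged. For the compounds shown here, the only earlier change to the six-membered ring was chloro, with a 5.3-fold higher number from compound 1 to compound 2 (0.73 log units; beyond the scatter), so these compounds show that a new group on that ring does not always raise the number. Nothing available here explains the difference between these two steps. Still open, from the compounds shown here alone, is whether a longer chain, an amine or a carboxylic acid on this carbon would leave the number similarly unchanged. Methyl on the other ring carbons also remains untested among the compounds shown.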